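Fluoro in Place of Ethyl on a Shared Core

The source may hold more compounds than are shown below. What is called first, only, known or untested is meant among the compounds shown, and "the series" means these compounds.

Compound 2 `CCc1ccc2nc(C(=O)Nc3c(F)cc(-c4cccc(F)c4)cc3F)c(C)c(O)c2c1` gives -0.35% in a functional assay on A-375 cells (Homo sapiens) for antiproliferative activity, read by MTT assay, with a stated time of 24 h, tested at 0.01 ug/mL; a higher number here means a stronger effect of the compound at the concentration tested, a lower number a weaker effect. Among the measured compounds shown here, of the two numbers measured so far this is nominally the lowest, yet compound 1 `Cc1ccc2nc(C(=O)Nc3c(F)cc(-c4cccc(F)c4)cc3F)c(C)c(O)c2c1`, which gives 0.1% in this assay, stands within the scatter of it, so the two cannot be told apart. For the measured compounds named here, the only measured step, a number 0.5 percentage points lower from compound 1 to compound 2 (within the scatter), shows that methyl in place of hydrogen on a saturated chain carbon bound to an aromatic carbon left the read-out unchanged. Compound 3 `Cc1c(C(=O)Nc2c(F)cc(-c3cccc(F)c3)cc2F)nc2ccc(F)cc2c1O` differs from compound 2 by fluoro in place of ethyl on an aromatic carbon. Going by the values given here, no measured step exchanges an ethyl for a fluoro, so the only guide is that both measured compounds sit near zero and the single step stayed within the scatter. The expected step is therefore none beyond the scatter, a number 0.4 percentage points higher from compound 2 to compound 3 (within the scatter). Compound 3 is expected to give 0% in this assay, within -8% to 8%.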

Compound 3, a percentage reported as inhibition, at one concentration (the size of the read-out at that concentration, not a potency): -0.35%
Beside the measured number, compound 3's estimate is 0.4 percentage points above it; measured number inside the range.
By their numbers in this assay, from the lowest: compounds 2, 3 and 1 (each within the scatter of the next).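

Fluoro in place of ethyl on this aromatic carbon gives no change at the digits printed from compound 2 to compound 3 (within the scatter) in this assay and fluoro in place of methyl gives a number 0.5 percentage points lower from compound 1 to compound 3 (within the scatter) as well. The earlier pair compared only two small carbon chains, whereas these steps show that a single fluorine atom on this carbon also yields a read-out that cannot be told apart from theirs, so this assay does not separate these three groups at this position. No measurement shown here offers an explanation for this result.

On these data alone, all three compounds read close to zero at a single concentration, so it remains open whether any group on this carbon can produce a clear effect. An amine, a carboxylic acid or a longer chain such as butyl at this position would test that question.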